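Adding a Methoxy Group Where Permeability Is Already High

The source may report more compounds than this note shows. Statements on the series, on what has been measured and on what is new or still open speak of the compounds shown alone.

Compound 1 `c1ccc(Oc2ccc3c(NCCCNCc4ccco4)ccnc3c2)cc1` is one of three related compounds measured in an ADME assay for permeability, using PAMPA, with a stated time of 30 min, at pH 7.4; on this read-out lower numbers stand for lower permeability and higher numbers for higher permeability. In this assay compound 1 gives 317 10^-6 cm/s. Compound 3 `COc1cccc(Oc2ccc3c(NCCCNCc4cccc(OC)c4O)ccnc3c2)c1` gives 317 10^-6 cm/s in this assay, the same number at the digits shown and within the scatter of compound 1; together these two stand highest of the three. Compound 2 `COc1ccc(F)cc1CNCCCNc1ccnc2cc(Cc3ccc(F)cc3)ccc12` gives 23 10^-6 cm/s in this assay, a far lower number, and that gap lies well beyond the scatter.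

Compound 4 `COc1ccc(Oc2ccc3c(NCCCNCc4ccco4)ccnc3c2)cc1` has not yet been measured in this assay. It differs from compound 1 in a single place: methoxy in place of hydrogen on an aromatic carbon. For the measured compounds named here, no measured pair differing only in this way is available, so the expectation rests on the values themselves. Methoxy groups absent from compound 1 are present in compound 3, which nonetheless gives 317 10^-6 cm/s. The expected step of a 1.1-fold lower number from compound 1 to compound 4 (0.05 log units; within the scatter) is therefore small, with no change beyond the scatter. Compound 4 is estimated at 280 10^-6 cm/s, within a range from 140 10^-6 cm/s to 500 10^-6 cm/s.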

Compound 4, apparent permeability: 317 10^-6 cm/s
For compound 4 the middle estimate is 1.1-fold (0.05 log units) below the measured one; low and high end bracket the measured number.
By their numbers in this assay, from the lowest: compound 2; then compounds 1, 3 and 4 (each within the scatter of the next).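

In this assay, for the compounds shown here, the change from phenoxy to 4-methoxyphenoxy gives no change at the digits printed from compound 1 to compound 4 (within the scatter) and so provides the first measured pair that differs in only one place. Compound 3 carries methoxy groups too, but it differs from compound 1 in several places, whereas this pair isolates a single methoxy group on an aromatic carbon, para to a large group, and the added group leaves the number where it stood. Nothing measured here explains why this position tolerates the change.

Going by these compounds, it remains open whether a different group at this position, such as an amine or a carboxylic acid, would also leave the number in place. On these data alone, it is also open whether methoxy would have so little effect on a compound with a much lower starting number, such as compound 2.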